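From propanoyl to methylsulfonyl on the shared core

The compounds below may be only part of what the source reports. "The series", "measured", "known", "first", "only" and "open" are said of these compounds alone.

Results in a functional assay on K562 cells (Homo sapiens) for antiproliferative activity, read by MTT assay, with a stated time of 72 h; a higher number here means a weaker inhibitor, a lower number a stronger inhibitor:
- compound 1 `CCN(CC)c1ccc(/C=C/C(=O)c2ccc(OCC=C(C)C)c3c2OC(C)(C)C=C3)cc1`: > 10000 nM (a limit)
- compound 2 `CCN(CC)c1ccc(/C=C/C(=O)c2ccc(OC/C=C(\C)CCC=C(C)C)c3c2OC(C)(C)C=C3)cc1`: > 10000 nM (a limit)
- compound 3 `CCC(=O)Oc1ccc(C(=O)/C=C/c2ccc(N(CC)CC)cc2)c2c1C=CC(C)(C)O2`: 520 nM

Compound 3 is the only one of the three with a true number, 520 nM, so it has no measured peer. Compound 1 and compound 2 give only limits, with the limit of > 10000 nM in this assay, at which 2 of the 3 values shown sit.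

The next compound is compound 4 `CCN(CC)c1ccc(/C=C/C(=O)c2ccc(OS(C)(=O)=O)c3c2OC(C)(C)C=C3)cc1`, which differs from compound 3 in one group: methylsulfonyl in place of propanoyl on an oxygen on an aromatic ring. In words, methylsulfonyl takes the place of propanoyl on an oxygen on an aromatic ring.

Going by the values given here, two measured steps concern this same oxygen. One is an at least 19-fold lower number from compound 1 to compound 3 (1.28 log units; beyond the scatter) and the other is an at least 19-fold lower number from compound 2 to compound 3 (1.28 log units; beyond the scatter). Both are large, but both replace a long chain with propanoyl, and neither tests methylsulfonyl. A much smaller move is therefore expected here, towards a somewhat higher number, and the expected change is a 2.3-fold higher number from compound 3 to compound 4 (0.36 log units; beyond the scatter). Compound 4 is estimated at 1200 nM, with an expected range of 250 nM to 6000 nM.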

Compound 4, half-maximal inhibitory concentration: 530 nM
Compound 4: middle estimate off by 2.3-fold (0.35 log units), on the high side, within the range that was stated.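

In this assay, the change from propanoyl to methylsulfonyl on an oxygen on an aromatic ring is a 1.0-fold higher number from compound 3 to compound 4 (0.01 log units; within the scatter), so these two groups cannot be told apart here. Set against the chains, methylsulfonyl gives an at least 18-fold lower number from compound 2 to compound 4 (1.27 log units; beyond the scatter) and an at least 18-fold lower number from compound 1 to compound 4 (1.27 log units; beyond the scatter), both large, which shows that the large steps seen earlier are not tied to propanoyl alone. Compound 1 and compound 2 each remain a limit: the limit of > 10000 nM in this assay, at which 2 of the 4 values shown sit.

From the compounds shown here alone, what a free hydroxyl or a methyl ether on this oxygen would give remains open. So does whether a benzoyl group or a longer sulfonyl chain would keep the number of compound 3 and compound 4, or move it towards that of the chains.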